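The source may report more compounds than this note shows. Statements on the series, on what has been measured and on what is new or still open speak of the compounds shown alone.

In a functional assay on MOLT-4 cells (Homo sapiens) for antiproliferative activity, with a stated time of 48 h (a lower number here means a stronger inhibitor, a higher number a weaker inhibitor), the three measured compounds stand as follows: compound 1 `C=C(Br)C(=O)Nc1ccc(/C=C/C(=O)c2ccccc2)cc1` gives 3100 nM; compound 2 `C=C(Br)C(=O)Nc1ccc(/C=C/C(=O)c2cccc(OC)c2)cc1` gives 850 nM; compound 3 `C=C(Br)C(=O)Nc1ccc(C(=O)/C=C/c2ccc(OC)cc2OC)cc1` gives 1500 nM.

Compound 1 and compound 2 share a core and differ in one place: methoxy in place of hydrogen on an aromatic carbon. That single change moved the number by a 3.6-fold lower number from compound 1 to compound 2 (0.56 log units; beyond the scatter). Compound 3 is built on a different core; the difference between the two cores is not broken down here. Its value in this assay lies close to that of compound 2, closer than the usual scatter of repeated measurements, so no order between compound 2 and compound 3 can be claimed.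

Compound 4 `C=C(Br)C(=O)Nc1ccc(C(=O)/C=C/c2ccc(OC)c(OC)c2OC)cc1` has not yet been measured. It differs from compound 3 by methoxy in place of hydrogen on an aromatic carbon. Going by the values given here, this is the same kind of change as the one from compound 1 to compound 2, but the surroundings are not identical: in compound 4 the entering methoxy sits ortho to two methoxy groups and meta to a large group, while in compound 2 it sat meta to a large group on a ring otherwise bare of methoxy groups. Among the compounds with values here, with only one earlier example of such a change, on a different core, the step from compound 3 to compound 4 in this assay is expected to be smaller than the earlier one, roughly a 1.7-fold lower number from compound 3 to compound 4 (0.22 log units; within the scatter), because compound 3 already starts from 1500 nM. On that basis compound 4 is estimated at 900 nM, with a plausible range from 350 nM to 2500 nM.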

Compound 4, half-maximal inhibitory concentration: 680 nM
Compound 4: middle estimate off by 1.3-fold (0.12 log units), on the high side; low and high end bracket the measured number.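

In this assay, putting methoxy in place of hydrogen on an aromatic carbon gave a 2.2-fold lower number from compound 3 to compound 4 (0.34 log units; beyond the scatter), so the number fell on this second core as it had on the first. The two steps point the same way, and their sizes cannot be told apart: the same change on two cores in this assay, a 3.6-fold lower number (0.56 log units; beyond the scatter) from compound 1 to compound 2 and a 2.2-fold lower number (0.34 log units; beyond the scatter) from compound 3 to compound 4, 1.7-fold (0.22 log units) apart, within the scatter of two such steps. This supports the change carrying over in direction between these two cores, but it rests on just two pairs, with the entering methoxy in different surroundings, so it gives neither a rule for other cores nor a reason why the number falls.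

What the compounds shown leave open is whether the effect belongs to methoxy in particular, since a hydroxyl group, an amine or a longer chain such as ethoxy in the same place could move the number differently, and whether methoxy would do the same elsewhere on these rings. The bromine-bearing amide is also the same in all four compounds, so its share in the activity cannot be read from them, and swapping the bromine for chlorine or hydrogen would be needed to address that.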